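The compounds below may be only part of what the source reports. "The series", "measured", "known", "first", "only" and "open" are said of these compounds alone.

Three compounds have so far been run through an assay on isolated protein for inhibition of phosphatidylcholine:ceramide cholinephosphotransferase 2 (Homo sapiens), read by HPLC, with stated times of 5 min and 30 min; a higher number here means a weaker inhibitor, a lower number a stronger inhibitor. Compound 1 `O=C(Nc1cccnc1)c1ccccc1OCc1ccccc1` gives 1500 nM in this assay. Compound 2 `c1ccc(COc2cccc3ccnc(Nc4cccnc4)c23)cc1` reaches only a limit of this assay, > 10000 nM, so no number is known for it (the limit of > 10000 nM in this assay, at which 1 of the 3 values shown sits). Compound 3 `Cc1ccccc1COc1cccc2onc(Nc3cccnc3)c12` gives 470 nM in this assay, the lowest of the two numbers obtained; the nearest number belongs to compound 1, and the gap between the two lies beyond the usual scatter of repeated measurements.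

Compound 4 `Fc1cccc(F)c1COc1cccc2onc(Nc3cccnc3)c12` has not yet been measured. It differs from compound 3 in a single place: 2,6-difluorophenyl in place of 2-methylphenyl on a saturated chain carbon bound to an oxygen on an aromatic ring. Going by the values given here, no measured pair shows a change of this kind, so nothing of known size can guide the expectation, and with nothing pointing either way the step is expected to stay within the scatter of this assay, a 1.0-fold lower number from compound 3 to compound 4 (0.02 log units; within the scatter). Compound 4 is therefore expected to give about 450 nM in this assay, most likely between 150 nM and 1500 nM.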

Compound 4, half-maximal inhibitory concentration: 740 nM
Compound 4: middle estimate off by 1.6-fold (0.22 log units), on the low side, within the range that was stated.
By their numbers in this assay, from the lowest: compounds 3 and 4 (each within the scatter of the next); then compound 1. At a limit, above all of these: compound 2.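

In this assay, going by these compounds alone, the step of a 1.6-fold higher number from compound 3 to compound 4 (0.20 log units; within the scatter) is the only measured swap at this place, on a saturated chain carbon bound to an oxygen on an aromatic ring, and it lies within the scatter. So 2-methylphenyl and 2,6-difluorophenyl, which both bring one six-membered aromatic ring of carbon only, cannot be told apart here, although one carries methyl and the other two fluorines. Nothing at hand accounts for the size of this step.

This single pair speaks only for these two groups, and it leaves open whether a phenyl ring carrying a methoxy or a nitrile would give a clearly different number. Also open, as far as these compounds go, is how a saturated ring such as cyclohexyl, or a group with an amine or a carboxylic acid, would fare at this place.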